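A Fluoro Added to Compound 3

A few compounds are considered here, and "the series" means these few. Any claim that something is new, unique, unknown or untested is made for them only; others in the source may bear on it.

Three related compounds have been measured so far in a functional assay on HL-60 cells (Homo sapiens) for inhibition, read by MTT assay, with a stated time of 72 h (on this read-out lower numbers stand for stronger inhibition and higher numbers for weaker inhibition), and their values lie close together. Compound 1 `Cc1nc(-c2cccc(F)c2)c(C(=O)N2CCN(c3cccc(Cl)c3)CC2)o1` gives 33.7 nM in this test. Compound 2 `Cc1nc(-c2ccc(F)cc2)c(C(=O)N2CCN(c3cc(Cl)cc(Cl)c3)CC2)o1` gives 52.1 nM in the same test. Compound 3 `Cc1nc(-c2ccccc2)c(C(=O)N2CCN(c3cc(Cl)cc(Cl)c3)CC2)o1` gives 41.8 nM there as well. Compound 3 has no clear rank, since its gaps to the other two lie within the usual scatter of repeated measurements.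

Compound 4 `Cc1nc(-c2cccc(F)c2)c(C(=O)N2CCN(c3cc(Cl)cc(Cl)c3)CC2)o1` is compound 3 with its phenyl group changed to 3-fluorophenyl. The change is fluoro in place of hydrogen on an aromatic carbon and amounts to fluoro in place of hydrogen on an aromatic carbon, meta to a large group.

Within the data shown here, one measured step bears directly on this swap. It shows a 1.2-fold lower number from compound 2 to compound 3 (0.10 log units; within the scatter) as a fluoro gives way to hydrogen, and that step stays within the scatter. Compound 2 does not carry the 3-fluorophenyl group, however, so the parallel is only partial. Compound 1 does carry it and gives 33.7 nM in spite of differing elsewhere too.

No shift beyond the scatter is therefore expected in this assay in either direction. The expected step is a 1.0-fold lower number from compound 3 to compound 4 (0.02 log units; within the scatter) and this estimate stays within the scatter. For compound 4 the estimated value is 40 nM with an expected range from 22 nM to 72 nM in this test.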

Compound 4, half-maximal inhibitory concentration: 41.7 nM
Estimate against measurement, compound 4: 1.0-fold (0.02 log units) below, within the range that was stated.
By their numbers in this assay, from the lowest: compounds 1, 4, 3 and 2 (each within the scatter of the next).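

In this assay, the fluoro can now be read on its own, with the rest of the molecule unchanged: phenyl to 3-fluorophenyl gives a 1.0-fold lower number from compound 3 to compound 4 (0.00 log units; within the scatter). Among these compounds, the position of the fluoro can also be compared for the first time, since 3-fluorophenyl in place of 4-fluorophenyl gives a 1.2-fold lower number from compound 2 to compound 4 (0.10 log units; within the scatter), so this test does not separate the two placements. Chloro in place of hydrogen on the other aromatic ring, with the 3-fluorophenyl group kept, gives a 1.2-fold higher number from compound 1 to compound 4 (0.09 log units; within the scatter), so that change also stays within the usual scatter of repeated measurements.

Nothing measured here gives a reason for these small steps. It remains open whether a group other than fluoro on this aromatic carbon, such as methoxy, an amine or a carboxylic acid, would shift the number beyond the scatter, since the four compounds shown carry only fluoro or hydrogen on this ring.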